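Bromo for hydrogen at the distal phenyl: cytotoxicity outlook

This account rests on a few compounds, and the source may have more. Where it says the series, first, only, none or still open, it means among the compounds named here.

Compound 2 `Cc1cc(O)c(C(=O)/C=C/c2ccc(Br)cc2)c(-c2ccccc2)c1C(=O)/C=C/c1ccc(Br)cc1` gives 10000 nM in an ADME assay on HEK293 cells (Homo sapiens) for cytotoxicity, read by MTT assay, with a stated time of 24 h; a higher number here means a weaker inhibitor, a lower number a stronger inhibitor; compound 1 `Cc1cc(O)c(C(=O)/C=C/c2ccc(Br)cc2)c(-c2ccc(OCc3ccccc3)cc2)c1C(=O)/C=C/c1ccc(Br)cc1` gives 20000 nM. The two numbers sit within the scatter of each other, as a 2.0-fold lower number from compound 1 to compound 2 (0.30 log units; within the scatter) shows. Compound 3 `Cc1cc(O)c(C(=O)/C=C/c2ccc(Br)cc2)c(-c2ccc(Br)cc2)c1C(=O)/C=C/c1ccc(Br)cc1` carries the change (bromo in place of hydrogen on an aromatic carbon). For the measured compounds named here, the only measured step, that from compound 1 to compound 2, touched the same ring and stayed within the scatter, so no step beyond the scatter is expected here either: the estimated step is no change at the digits printed from compound 2 to compound 3 (within the scatter). Compound 3 is therefore expected near 10000 nM, with a range from 4000 nM to 25000 nM.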

Compound 3, half-maximal inhibitory concentration: 30000 nM
The estimate for compound 3 lay 3.0-fold (0.48 log units) below the measured number; measured number outside the range, above it.
By their numbers in this assay, from the lowest: compounds 2, 1 and 3 (each within the scatter of the next, the first and the last beyond it).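

With the change from phenyl to 4-bromophenyl, this position gives its first step beyond the scatter, with a 3.0-fold higher number from compound 2 to compound 3 (0.48 log units; beyond the scatter) in this assay. Bromo in place of benzyloxy gives a 1.5-fold higher number from compound 1 to compound 3 (0.18 log units; within the scatter), so these two groups are not separated here, and the hydrogen of compound 2 stands apart only from the bromo of compound 3. Nothing at hand bears on the origin of this step. Still open, from the compounds shown here alone, is whether chloro, an amine, a carboxylic acid or a longer chain at this position would read like compound 2 or compound 3.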